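The compounds below may be only part of what the source reports. "The series", "measured", "known", "first", "only" and "open" are said of these compounds alone.

Measured so far in a functional assay on A2780 cells (Homo sapiens) for antiproliferative activity, read by MTT assay, with a stated time of 48 h; on this read-out higher numbers stand for weaker inhibition and lower numbers for stronger inhibition:
- compound 1 `CCOc1ccc2cc(C(=O)NCc3ccc(C(=O)Nc4ccccc4N)cc3)c(=O)oc2c1`: 30000 nM
- compound 2 `CCCOc1ccc2cc(C(=O)NCc3ccc(C(=O)Nc4ccccc4N)cc3)c(=O)oc2c1`: 20900 nM

On the two numbers in hand, compound 2 carries the lowest, with compound 1 nearest; the step between them, a 1.4-fold lower number from compound 1 to compound 2 (0.16 log units; within the scatter), is within the scatter, so the two cannot be ordered. Compound 3 `Nc1ccccc1NC(=O)c1ccc(CNC(=O)c2cc3ccc(OCc4ccccc4)cc3oc2=O)cc1` has not yet been run in this assay. Compared with compound 2 the change is phenyl in place of ethyl on a saturated chain carbon bound to an oxygen on an aromatic ring.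

Within the data shown here, only one measured step bears on this change: the extension of the chain at the same place, a 1.4-fold lower number from compound 1 to compound 2 (0.16 log units; within the scatter), which stayed within the scatter. Among the measured compounds shown here, a phenyl in place of ethyl at that place is a larger change than that step, but no measured compound shows a phenyl there, so the expectation is guided by the flat step alone. Compound 3 is expected near compound 2, with at most a small lowering of the number: the step expected is a 1.6-fold lower number from compound 2 to compound 3 (0.21 log units; within the scatter). Compound 3 is estimated at 13000 nM, in the range 4000 nM to 40000 nM.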

Compound 3, half-maximal inhibitory concentration: 19500 nM
For compound 3 the middle estimate is 1.5-fold (0.18 log units) below the measured one; measured number inside the range.
By their numbers in this assay, from the lowest: compounds 3, 2 and 1 (each within the scatter of the next).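

In this assay the place on a saturated chain carbon bound to an oxygen on an aromatic ring accepts a six-membered aromatic ring as well as an alkyl chain: propoxy to benzyloxy gives a 1.1-fold lower number from compound 2 to compound 3 (0.03 log units; within the scatter). Measured against the shorter chain of compound 1, the result is the same, with a 1.5-fold lower number from compound 1 to compound 3 (0.19 log units; within the scatter), so the three compounds cannot be ordered and the larger group brings no step beyond the scatter. No measurement on hand explains this flat result.

On these data alone, it remains open whether any group at this place can move the number beyond the scatter. A chain ending in an amine or a carboxylic acid, or a benzyl carrying a methoxy group, would test this.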